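Fluoro in place of chloro: one small swap

A few compounds are considered here, and "the series" means these few. Any claim that something is new, unique, unknown or untested is made for them only; others in the source may bear on it.

Going by the values given here, in a functional assay on HCT-116 cells (Homo sapiens) for cytotoxicity, read by MTT assay, with a stated time of 48 h (a higher number here means a weaker inhibitor, a lower number a stronger inhibitor), compound 1 `CNC(=O)c1ccc(Sc2ccc(NC(=O)Nc3ccc(Cl)c(C(F)(F)F)c3)cc2)nc1` gives 5290 nM, the only true number available so far. Compound 2 `CNC(=O)c1ccc(Sc2ccc(NC(=S)Nc3ccc(OC(F)(F)F)cc3)cc2)nc1` returns only a limit of the assay, > 100000 nM. The next compound to be tested, compound 3 `CNC(=O)c1ccc(Sc2ccc(NC(=O)Nc3ccc(F)c(C(F)(F)F)c3)cc2)nc1`, keeps the core of compound 1 and carries fluoro in place of chloro on an aromatic carbon, ortho to a trifluoromethyl group and para to a large group: fluoro in place of chloro on an aromatic carbon. Among the compounds with values here, no measured pair shows what this exchange does, so the data set no direction for it. With compound 1 at 5290 nM as the only anchor, a shift no larger than the usual scatter of this assay is expected. The estimated step is a 1.1-fold higher number from compound 1 to compound 3 (0.05 log units; within the scatter). For compound 3 the expected value is 6000 nM, with an estimated range from 2500 nM to 14000 nM.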

Compound 3, half-maximal inhibitory concentration: 5800 nM
For compound 3 the middle estimate is 1.0-fold (0.01 log units) above the measured one, and the stated range covers the measured number.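

In this assay, fluoro in place of chloro on this aromatic carbon, ortho to a trifluoromethyl group and para to a large group, gives a 1.1-fold higher number from compound 1 to compound 3 (0.04 log units; within the scatter) and so leaves the two compounds unranked. Going by these compounds alone, this is the first measured pair that differs in one place only, and it shows that, with the rest of the core of compound 1 kept, chloro and fluoro cannot be told apart at this position in this cell test. Nothing measured here accounts for this result.

The compounds shown leave open how this carbon responds to a group of another kind, such as a methoxy group, a nitrile or an amine, or to plain hydrogen. They also leave open whether chloro and fluoro would still match if a methyl group replaced the trifluoromethyl group.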